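Adding a Third Methoxy to a Weak Cytotoxic Compound

This account rests on a few compounds, and the source may have more. Where it says the series, first, only, none or still open, it means among the compounds named here.

In a functional assay on A549 cells (Homo sapiens) for cytotoxicity, read by sulforhodamine B assay, with a stated time of 72 h (a lower number here means that less compound is needed, a higher number that more compound is needed for the effect), compound 1 `Cc1cccc(-c2cc3occ(C)c3c(=O)o2)c1` gives 53.8 uM, a weak result that takes a lot of compound to reach. Compound 2 `COc1cc(OC)cc(-c2cc3occ(C)c3c(=O)o2)c1`, with two methoxy groups on its aromatic ring, gives > 69.9 uM, which is a limit of the assay and not a number. Its true value is therefore unknown.

Compound 3 `COc1cc(-c2cc3occ(C)c3c(=O)o2)cc(OC)c1OC` has methoxy in place of hydrogen on an aromatic carbon, ortho to two methoxy groups and para to a large group (methoxy in place of hydrogen on an aromatic carbon).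

Among the compounds with values here, no measured step shows what such a change does. Within the data shown here, the only firm number is that of compound 1, 53.8 uM, so only a small shift towards less compound needed is expected in this assay. The result may again be only a limit. The estimated move is an at least 1.3-fold lower number from compound 2 to compound 3 (0.14 log units; that floor lies within the scatter). Compound 3 is expected at 50 uM, within an estimated range of 15 uM to 90 uM.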

Compound 3, concentration for half-maximal effect: 63.3 uM
The estimate for compound 3 lay 1.3-fold (0.10 log units) below the measured number; measured number inside the range.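

Adding a methoxy at this carbon, ortho to two methoxy groups and para to a large group, gives a firm reading: in this assay compound 3 gives 63.3 uM, which is a true number and not a limit. The change can be stated only as an at least 1.1-fold lower number from compound 2 to compound 3 (0.04 log units; that floor lies within the scatter) and this floor does not show how large the real step is, so even a three-methoxy ring stays weak here. The step has only a floor because compound 2 sits at a limit of the assay: the limit of > 69.9 uM in this assay, at which 1 of the 3 values shown sits.

On these data alone, it remains open whether an amine or a hydroxyl on this same carbon would need clearly less compound in this assay. Also open, as far as these compounds go, is what this methoxy would do on a ring without the other two methoxy groups.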